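One methoxyphenyl swap and its expected effect

The source may hold more compounds than are shown below. What is called first, only, known or untested is meant among the compounds shown, and "the series" means these compounds.

Compound 1 `COc1ccccc1Oc1c(N)nc(-c2ccc(C)cc2)nc1OCCO` and compound 2 `COc1cccc(-c2nc(N)c(Oc3ccccc3OC)c(OCCO)n2)c1` share a core and differ in one group. In a functional assay on B16 cells (Mus musculus) for cytotoxicity, read by CCK-8 assay, with a stated time of 24 h (on this read-out higher numbers stand for weaker inhibition and lower numbers for stronger inhibition), compound 1 gives 8430 nM, while compound 2 gives 30500 nM, the higher number of the two and so the weaker inhibition. Within the data shown here, the only measured step is a 3.6-fold higher number from compound 1 to compound 2 (0.56 log units; beyond the scatter), with 3-methoxyphenyl in place of 4-methylphenyl on an aromatic carbon. It is modest but beyond the scatter.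

Compound 3 `COc1ccc(-c2nc(N)c(Oc3ccccc3OC)c(OCCO)n2)cc1` differs from compound 2 in one place: 4-methoxyphenyl in place of 3-methoxyphenyl on an aromatic carbon. The new group stays on the same aromatic carbon, between two ring nitrogen atoms. The measured step bears on this change only in part. Among the measured compounds shown here, the 4-methoxyphenyl group matches the 4-methylphenyl of compound 1 in where its substituent sits and keeps the methoxy of compound 2, but no measured pair isolates that shift alone. Going by a 3.6-fold higher number from compound 1 to compound 2 (0.56 log units; beyond the scatter) seen so far, a partial return towards compound 1 seems likely. In this assay the estimated change is a 2.0-fold lower number from compound 2 to compound 3 (0.31 log units; beyond the scatter), a modest step at most as large as the measured one. For compound 3 the expected value is 15000 nM, with an estimated range of 6000 nM to 35000 nM.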

Compound 3, half-maximal inhibitory concentration: 18100 nM
Beside the measured number, compound 3's estimate is 1.2-fold (0.08 log units) below it, and the stated range covers the measured number.
By their numbers in this assay, from the lowest: compound 1; then compounds 3 and 2 (each within the scatter of the next).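

In this assay, exchanging 3-methoxyphenyl for 4-methoxyphenyl gives a 1.7-fold lower number from compound 2 to compound 3 (0.23 log units; within the scatter), so these two isomers, which contain the same atoms joined differently, cannot be told apart here, and the placement of the methoxy group on this phenyl ring shows no clear effect. The comparison between 4-methylphenyl and 4-methoxyphenyl is new and cleaner than the earlier step, as only methoxy replaces methyl in the same named arrangement, and it gives a 2.1-fold higher number from compound 1 to compound 3 (0.33 log units; beyond the scatter), a modest weakening that lies beyond the scatter. Nothing available explains why methoxy gives a higher number than methyl in this comparison.

The compounds shown leave open how other groups in place of the methyl or methoxy would compare, such as an ethoxy group, a chlorine atom or a dimethylamino group. They also leave open whether a longer chain or a carboxylic acid in place of the 2-hydroxyethoxy group would change the number, and whether the difference between methyl and methoxy would persist on such a compound.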